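The source may report more compounds than this note shows. Statements on the series, on what has been measured and on what is new or still open speak of the compounds shown alone.

Compound 1 `N#CC1=C(N)Oc2c(N)cc3nc4ccccc4nc3c2C12C(=O)N(Cc1cnnn1-c1ccccc1Cl)c1ccccc12` and compound 2 `N#CC1=C(N)Oc2c(N)cc3nc4ccccc4nc3c2C12C(=O)N(Cc1cnnn1-c1ccccc1Br)c1ccccc12` share one core and differ only in the group on the aromatic nitrogen of the triazole. In a functional assay on HepG2 cells (Homo sapiens) for antiproliferative activity, read by MTT assay, with a stated time of 48 h (a higher number here means a weaker inhibitor, a lower number a stronger inhibitor), compound 1 gives 33500 nM, and in this assay compound 2 gives 38000 nM. For the measured compounds named here, the only step measured so far is a 1.1-fold higher number from compound 1 to compound 2 (0.05 log units; within the scatter), so compound 2 has the higher of the two numbers, but the gap to compound 1 is within the scatter and the two compounds cannot be ordered.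

Compound 3 `N#CC1=C(N)Oc2c(N)cc3nc4ccccc4nc3c2C12C(=O)N(Cc1cnnn1-c1cccc(C(F)(F)F)c1)c1ccccc12` is the next member. Its change from compound 2 is 3-(trifluoromethyl)phenyl in place of 2-bromophenyl on an aromatic nitrogen. Going by the values given here, the one measured step bears on it only in that it also exchanges the substituent on that phenyl ring and left this assay essentially unchanged; no measured step tests a trifluoromethyl group or the new position on the ring. On that basis the expected step is a 1.1-fold lower number from compound 2 to compound 3 (0.02 log units; within the scatter), that is, no change beyond the scatter. Compound 3 is therefore estimated at 36000 nM in this assay, with a range from 14000 nM to 90000 nM.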

Compound 3, half-maximal inhibitory concentration: 15800 nM
Estimate against measurement, compound 3: 2.3-fold (0.36 log units) above; measured number inside the range.
By their numbers in this assay, from the lowest: compound 3; then compounds 1 and 2 (each within the scatter of the next).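

In this assay, the substituted phenyl on the aromatic nitrogen can shift the number beyond the scatter: 3-(trifluoromethyl)phenyl in place of 2-bromophenyl gives a 2.4-fold lower number from compound 2 to compound 3 (0.38 log units; beyond the scatter), and 3-(trifluoromethyl)phenyl in place of 2-chlorophenyl gives a 2.1-fold lower number from compound 1 to compound 3 (0.33 log units; beyond the scatter), both modest steps, which make compound 3 the strongest of the three. The exchange of chloro for bromo had shown no such shift, since its step of a 1.1-fold higher number from compound 1 to compound 2 (0.05 log units; within the scatter) stays within the scatter. Both new steps, however, alter the substituent and its place on the phenyl ring together, and no evidence on these compounds accounts for the lower number.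

The compounds shown leave open whether the trifluoromethyl group or its place on the ring carries the step, a question that a pair such as 3-bromophenyl and 2-(trifluoromethyl)phenyl would address. They also leave open how an unsubstituted phenyl, or a phenyl bearing an amine or a carboxylic acid, would read in this assay.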